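Piperidin-1-yl Replaces Fluoro: Expected Tracheal Inhibition

This account rests on a few compounds, and the source may have more. Where it says the series, first, only, none or still open, it means among the compounds named here.

Measured compounds:
- compound 1, `CO[C@@]12CCN(C)C[C@H]1[C@H](c1ccc(Br)cc1)C(C#N)=C(N)O2`: in a functional assay on trachea (Cavia porcellus) (on this read-out higher numbers stand for weaker inhibition and lower numbers for stronger inhibition), compound 1 gives 7900 nM
- compound 2, `CO[C@@]12CCN(C)C[C@H]1[C@H](c1ccc(F)cc1)C(C#N)=C(N)O2`: in this assay compound 2 gives 19400 nM

For the measured compounds named here, compound 2 has the higher of the two numbers; its only neighbour is compound 1, and the change from bromo to fluoro produced a 2.5-fold higher number from compound 1 to compound 2 (0.39 log units; beyond the scatter). Compound 3, `CO[C@@]12CCN(C)C[C@H]1[C@H](c1ccc(N3CCCCC3)cc1)C(C#N)=C(N)O2`, is not yet measured and differs from compound 2 in one place: piperidin-1-yl in place of fluoro on an aromatic carbon. Going by the values given here, the single measured step that bears on this position is the modest one from compound 1 to compound 2, which shows that exchanging the group on this aromatic carbon moved the number only a little. Among the compounds with values here, no measured pair covers the exchange of fluoro for piperidin-1-yl, so the size of this step is uncertain. Compound 1, with bromo at this place, gives 7900 nM, which supports a slight lean toward a lower number. Compound 3 is therefore expected to give 12000 nM, between 4000 nM and 40000 nM, an expected step of a 1.6-fold lower number from compound 2 to compound 3 (0.21 log units; within the scatter).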

Compound 3, half-maximal inhibitory concentration: 19000 nM
Compound 3: middle estimate off by 1.6-fold (0.20 log units), on the low side; low and high end bracket the measured number.
By their numbers in this assay, from the lowest: compound 1; then compounds 3 and 2 (each within the scatter of the next).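

In this assay, putting the piperidin-1-yl ring on this aromatic carbon in place of the single fluorine atom gives a 1.0-fold lower number from compound 2 to compound 3 (0.01 log units; within the scatter), so a far larger group here leaves the number within the scatter of the fluoro compound. Against bromo, the same ring gives a 2.4-fold higher number from compound 1 to compound 3 (0.38 log units; beyond the scatter), which leaves bromo as the one group of the three that stands apart, and it shows that group size alone does not order the numbers at this position. Nothing available explains why bromo differs from the other two groups.

On these data alone, it remains open whether bromo's lower number is specific to bromo or would also appear with chloro or iodo. As far as these compounds go, it is also open how an open-chain amine such as dimethylamino, a morpholin-4-yl ring or a carboxylic acid would behave on this carbon.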